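Aryl swap on the shared core: methoxyphenyl for difluorophenyl

The compounds below may be only part of what the source reports. "The series", "measured", "known", "first", "only" and "open" are said of these compounds alone.

In a functional assay on A549 cells (Homo sapiens) for antiproliferative activity, read by MTT assay, with a stated time of 72 h (a higher number here means a weaker inhibitor, a lower number a stronger inhibitor), compound 1 `COc1cc(-n2cnc3ccc(-c4cc(F)ccc4F)cc32)cc(OC)c1OC` gives 7940 nM, the higher of the two numbers recorded, the other belonging to compound 2 `COc1cc(-n2cnc3ccc(-c4cccc(Cl)c4)cc32)cc(OC)c1OC`, which in this assay gives 7050 nM. Compound 3 `COc1cc(-n2cnc3ccc(-c4ccc(Cl)cc4)cc32)cc(OC)c1OC` reaches only the limit of this assay, > 10000 nM, as noted in the limit of > 10000 nM in this assay, at which 1 of the 3 values shown sits. The step of a 1.1-fold lower number from compound 1 to compound 2 (0.05 log units; within the scatter) stays within the scatter; the steps of an at least 1.2-fold higher number from compound 1 to compound 3 (0.10 log units; that floor lies within the scatter) and an at least 1.4-fold higher number from compound 2 to compound 3 (0.15 log units; that floor lies within the scatter) have floors that also lie within the scatter, so none of the three aryl changes separates clearly from another.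

Compound 4 `COc1ccc(-c2ccc3ncn(-c4cc(OC)c(OC)c(OC)c4)c3c2)cc1` differs from compound 1 by 4-methoxyphenyl in place of 2,5-difluorophenyl on an aromatic carbon. The nearest measured precedent is the move to compound 3, where a single group on the same position of the entering ring gave only a limit. Compound 4 is therefore expected to sit near compound 1 or somewhat higher, with a fair chance that this assay again reports only a limit; the expected step is a 1.5-fold higher number from compound 1 to compound 4 (0.18 log units; within the scatter), and the estimate for compound 4 is 12000 nM within 5000 nM to 30000 nM.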

Compound 4, half-maximal inhibitory concentration: > 10000 nM
Compound 4 ended at the assay's limit (the forecaster's own chance of this, stated with the estimate: 50%); the middle value is on the limit's open side.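

In this assay the 4-methoxyphenyl group, like the 4-chlorophenyl group, ends at a limit and not at a number, so two different groups in this place now share that outcome: the limit of > 10000 nM in this assay, at which 2 of the 4 values shown sit. The two readable steps, an at least 1.2-fold higher number from compound 1 to compound 4 (0.10 log units; that floor lies within the scatter) and an at least 1.4-fold higher number from compound 2 to compound 4 (0.15 log units; that floor lies within the scatter), give only floors, so the change from 2,5-difluorophenyl or 3-chlorophenyl to 4-methoxyphenyl is not shown to be a real loss. The step between the two limits cannot be read, which leaves methoxy and chloro in that place unordered.

With only limits and values within the scatter, the compounds shown give no ranking of these aryl groups. On these data alone, whether an amine or a carboxylic acid on this phenyl ring would give a number clearly apart from those of compound 1 and compound 2 stays open.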